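Working notes: reinstating a carbamoyl group in the series

This account rests on a few compounds, and the source may have more. Where it says the series, first, only, none or still open, it means among the compounds named here.

Among the measured compounds shown here, compound 2 `COc1ncc(-c2ccc3nc(NC4CC4)sc3c2)cc1NS(=O)(=O)c1ccc(F)cc1` gives 1500 nM in a functional assay on U-87MG ATCC cells for antiproliferative activity against U-87 MG (Homo sapiens), read by MTT assay, with a stated time of 72 h (a higher number here means a weaker inhibitor, a lower number a stronger inhibitor), the higher of the two numbers measured so far, while compound 1 `COc1ncc(-c2ccc3nc(NC(=O)NCCN4CCCC4)sc3c2)cc1NS(=O)(=O)c1ccc(F)cc1` gives 360 nM. For the measured compounds named here, the single measured step, a 4.2-fold higher number from compound 1 to compound 2 (0.62 log units; beyond the scatter), bears directly on the change to compound 3 `COc1ncc(-c2ccc3nc(NC(=O)NC4CC4)sc3c2)cc1NS(=O)(=O)c1ccc(F)cc1`, which applies (cyclopropylcarbamoyl in place of cyclopropyl on a nitrogen on an aromatic ring). That earlier step removed a carbamoyl-linked chain and weakened activity; compound 3 puts a carbamoyl back, so a move toward lower numbers is expected, though perhaps smaller since the amine part is now cyclopropyl rather than 2-(pyrrolidin-1-yl)ethyl. Compound 3 is therefore expected near 500 nM, within 150 nM to 1500 nM, an estimated step of a 3.0-fold lower number from compound 2 to compound 3 (0.48 log units; beyond the scatter).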

Compound 3, half-maximal inhibitory concentration: 520 nM
Compound 3: the middle estimate sits 1.0-fold (0.02 log units) below what was measured, and the stated range covers the measured number.
By their numbers in this assay, from the lowest: compounds 1 and 3 (each within the scatter of the next); then compound 2.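

On a nitrogen on an aromatic ring, in this assay, cyclopropylcarbamoyl in place of cyclopropyl gives a 2.9-fold lower number from compound 2 to compound 3 (0.46 log units; beyond the scatter), so in this pair the carbamoyl accounts for a step without any 2-(pyrrolidin-1-yl)ethyl group. On the amide-type nitrogen, cyclopropyl in place of 2-(pyrrolidin-1-yl)ethyl gives a 1.4-fold higher number from compound 1 to compound 3 (0.16 log units; within the scatter), so these two groups are not told apart in this assay. Nothing available explains either step. Still open, from the compounds shown here alone, is how other groups on the amide-type nitrogen, such as a longer alkyl chain, a morpholine or a carboxylic acid, would compare.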